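The compounds below may be only part of what the source reports. "The series", "measured", "known", "first", "only" and "open" are said of these compounds alone.

Measured in a functional assay on SMMC-7721 cells (Homo sapiens) for antiproliferative activity, read by MTT assay, with a stated time of 48 h; a higher number here means a weaker inhibitor, a lower number a stronger inhibitor:
compound 1 `CC(C)=CCC[C@]1(C)/C=C/[C@@H](OC(=O)C=C(C)C)[C@](C)(O)/C=C/C(=O)/C(C(=O)O)=C\C1`: > 10000 nM, a limit of the assay, not a number
compound 2 `CC(C)=CCC[C@]1(C)/C=C/[C@@H](OC(=O)C=C(C)C)[C@](C)(O)/C=C/C(=O)/C(CN(C)C)=C\C1`: 820 nM
compound 3 `CC(C)=CCC[C@]1(C)/C=C/[C@@H](OC(=O)C=C(C)C)[C@](C)(O)/C=C/C(=O)/C(CN=[N+]=[N-])=C\C1`: 3080 nM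

Compound 1 stands only at a limit in this assay: the limit of > 10000 nM in this assay, at which 1 of the 3 values shown sits. Both measured steps start from compound 1 and replace the carboxy: an at least 12-fold lower number from compound 1 to compound 2 (1.08 log units; beyond the scatter) and an at least 3.2-fold lower number from compound 1 to compound 3 (0.51 log units; beyond the scatter). Between those two replacements the difference is a 3.8-fold higher number from compound 2 to compound 3 (0.57 log units; beyond the scatter).

Compound 4 `CC(C)=CCC[C@]1(C)/C=C/[C@@H](OC(=O)C=C(C)C)[C@](C)(O)/C=C/C(=O)/C(C(=O)N2CCCC2)=C\C1` differs from compound 1 by pyrrolidin-1-yl in place of hydroxy on a carbonyl carbon. The carboxy is again replaced, here by (pyrrolidin-1-yl)carbonyl, and a lower number is expected because an at least 12-fold lower number from compound 1 to compound 2 (1.08 log units; beyond the scatter) and an at least 3.2-fold lower number from compound 1 to compound 3 (0.51 log units; beyond the scatter) both ran that way, with the size uncertain between those two. Estimated for compound 4: 2500 nM (range 700 nM to 10000 nM). That expected step is an at least 4.0-fold lower number from compound 1 to compound 4 (0.60 log units; beyond the scatter).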

Compound 4, half-maximal inhibitory concentration: 14900 nM
Beside the measured number, compound 4's estimate is 6.0-fold (0.78 log units) below it; the measured number lies above the stated range.
By their numbers in this assay, from the lowest: compound 2; then compound 3; then compound 4.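

In this assay, the (pyrrolidin-1-yl)carbonyl on the double-bonded ring carbon compares poorly with the other two replacements of the carboxy: a 4.8-fold higher number from compound 3 to compound 4 (0.68 log units; beyond the scatter), and an 18-fold higher number from compound 2 to compound 4 (1.26 log units; beyond the scatter). Replacing the carboxy therefore does not by itself give a low number; the entering group matters. The step from compound 1 cannot be read, since its value is a limit: the limit of > 10000 nM in this assay, at which 1 of the 4 values shown sits.

On these data alone, whether the pyrrolidine ring or the carbonyl sets the higher number of compound 4 stays open. A (pyrrolidin-1-yl)methyl group on the same carbon would separate the two.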